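Methyl for chloro on a shared amide-bearing ring

This account rests on a few compounds, and the source may have more. Where it says the series, first, only, none or still open, it means among the compounds named here.

Three compounds share one core and differ only in the aryl group on the amide nitrogen. Compound 1 `CN1C[C@H](C(=O)Nc2cccc(Cl)c2)[C@@H](c2ccc(/C=C/C(=O)Nc3ccccc3N)cc2)C1` is the parent; in an in vitro ADME assay on microsomes from liver (Homo sapiens) for pharmacokinetics, read by LC-MS, with a stated time of 10 min, tested at 1 uM (on this read-out higher numbers stand for fast clearance and lower numbers for slow clearance), compound 1 gives 7 mL/min/kg. Compound 2 `Cc1cccc(NC(=O)[C@H]2CN(C)C[C@@H]2c2ccc(/C=C/C(=O)Nc3ccccc3N)cc2)c1` carries methyl in place of chloro on an aromatic carbon and in this assay compound 2 gives 14 mL/min/kg, a change of a 2.0-fold higher number from compound 1 to compound 2 (0.30 log units; within the scatter). Compound 3 `CN1C[C@H](C(=O)Nc2ccc(F)c(Cl)c2)[C@@H](c2ccc(/C=C/C(=O)Nc3ccccc3N)cc2)C1` differs from compound 1 by fluoro in place of hydrogen on an aromatic carbon; in this assay compound 3 gives 15 mL/min/kg, which is a 2.1-fold higher number from compound 1 to compound 3 (0.33 log units; beyond the scatter). Between compound 2 and compound 3 the gap is a 1.1-fold higher number from compound 2 to compound 3 (0.03 log units; within the scatter).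

Compound 4 `Cc1cc(NC(=O)[C@H]2CN(C)C[C@@H]2c2ccc(/C=C/C(=O)Nc3ccccc3N)cc2)ccc1F` has not been measured. It differs from compound 3 by methyl in place of chloro on an aromatic carbon. This is the same kind of change as from compound 1 to compound 2, but the place is not identical: in compound 4 the methyl sits ortho to a fluoro group as well as meta to a large group. Starting from compound 3, the step is expected to be a 1.5-fold higher number from compound 3 to compound 4 (0.17 log units; within the scatter), resting on the earlier step of a 2.0-fold higher number from compound 1 to compound 2 (0.30 log units; within the scatter). In this assay compound 4 is estimated at 22 mL/min/kg, with a range from 10 mL/min/kg to 45 mL/min/kg.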

Compound 4, clearance: 15 mL/min/kg
Estimate against measurement, compound 4: 1.5-fold (0.17 log units) above; the measured number falls inside the stated range.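

Putting methyl in place of chloro on the 3-chloro-4-fluorophenyl group gives no change at the digits printed from compound 3 to compound 4 (within the scatter), and this step agrees with the same change made on the 3-chlorophenyl group: the same change on two cores in this assay, a 2.0-fold higher number (0.30 log units; within the scatter) from compound 1 to compound 2 and no change at the digits printed (within the scatter) from compound 3 to compound 4, 2.0-fold (0.30 log units) apart, within the scatter of two such steps

Putting fluoro in place of hydrogen on the 3-methylphenyl group gives a 1.1-fold higher number from compound 2 to compound 4 (0.03 log units; within the scatter), and this step also agrees with its earlier counterpart: the same change on two cores in this assay, a 2.1-fold higher number (0.33 log units; beyond the scatter) from compound 1 to compound 3 and a 1.1-fold higher number (0.03 log units; within the scatter) from compound 2 to compound 4, 2.0-fold (0.30 log units) apart, within the scatter of two such steps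

The whole replacement of 3-chlorophenyl by 4-fluoro-3-methylphenyl gives a 2.1-fold higher number from compound 1 to compound 4 (0.33 log units; beyond the scatter); across these four compounds, each change can be carried over without a detectable difference, but steps this small cannot show that its size is truly the same or that it would hold on any other group.

The compounds shown leave open how a methoxy or a nitrile in place of the chloro would read in this assay. They also leave open what an amine at that place on the ring would do.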